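From a Six- to an Eight-Membered Amine Ring

The compounds below may be only part of what the source reports. "The series", "measured", "known", "first", "only" and "open" are said of these compounds alone.

Measured compounds:
Compound 1: `CC(C(=O)NCc1ccc(C(F)(F)F)nc1N(C)C)c1ccc(NS(C)(=O)=O)c(F)c1`, 2390 nM
Compound 2: `CC(C(=O)NCc1ccc(C(F)(F)F)nc1N1CCCC1)c1ccc(NS(C)(=O)=O)c(F)c1`, 211 nM
Compound 3: `CC(C(=O)NCc1ccc(C(F)(F)F)nc1N1CCC(C)(C)CC1)c1ccc(NS(C)(=O)=O)c(F)c1`, 8 nM

All three were tested in a functional assay on CHO-K1 cells for antagonist activity at transient receptor potential cation channel subfamily V member 1 (Homo sapiens), read by FLIPR; on this read-out lower numbers stand for stronger inhibition and higher numbers for weaker inhibition. Compound 3 stands lowest of the three, set apart from the others by a 26-fold lower number from compound 2 to compound 3 (1.42 log units; beyond the scatter) and by a 300-fold lower number from compound 1 to compound 3 (2.48 log units; beyond the scatter).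

Compound 4, `CC(C(=O)NCc1ccc(C(F)(F)F)nc1N1CCCCCCC1)c1ccc(NS(C)(=O)=O)c(F)c1`, is built from the same atoms as compound 3, joined differently: a group of 8 heavy atoms (7 carbon, 1 nitrogen; one eight-membered non-aromatic ring with 1 hetero atom) in place of a group of 8 heavy atoms (7 carbon, 1 nitrogen; one six-membered non-aromatic ring with 1 hetero atom), on an aromatic carbon. Within the data shown here, two measured steps bear on this change, an 11-fold lower number from compound 1 to compound 2 (1.05 log units; beyond the scatter) and a 26-fold lower number from compound 2 to compound 3 (1.42 log units; beyond the scatter), each a large fall as the amine ring grew. Neither step, however, tests a ring widened without added atoms, so their size cannot simply be carried over. A small rise, or no step beyond the scatter, is expected: a 2.5-fold higher number from compound 3 to compound 4 (0.40 log units; beyond the scatter). Compound 4 is estimated at 20 nM, in the range 5 nM to 100 nM.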

Compound 4, half-maximal inhibitory concentration: 27.8 nM
Compound 4: middle estimate off by 1.4-fold (0.14 log units), on the low side; low and high end bracket the measured number.
By their numbers in this assay, from the lowest: compound 3; then compound 4; then compound 2; then compound 1.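

With the atoms unchanged, a 3.5-fold higher number from compound 3 to compound 4 (0.54 log units; beyond the scatter) shows that how these atoms are joined at this position matters, not merely how many there are. Both a 7.6-fold lower number from compound 2 to compound 4 (0.88 log units; beyond the scatter) and an 86-fold lower number from compound 1 to compound 4 (1.93 log units; beyond the scatter) show that the eight-membered ring still keeps much of the fall seen with the larger amines. Nothing measured here accounts for the gap between the two eight-atom groups. Open, from the compounds shown here alone, is where plain piperidin-1-yl, without its two methyl groups, would stand, which would separate ring size from those methyls, and where seven-membered azepan-1-yl would fall.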